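A few compounds are considered here, and "the series" means these few. Any claim that something is new, unique, unknown or untested is made for them only; others in the source may bear on it.

Measured in a functional assay on LNCaP cells (Homo sapiens) for cytotoxicity, read by MTT assay, with a stated time of 72 h; a higher number here means a weaker inhibitor, a lower number a stronger inhibitor:
Compound 1 `N[C@H]1CC[C@H](Nc2c(C(=O)NCc3ccc(F)cc3)nc(N3CCCCS3(=O)=O)c3cccnc23)CC1`: 8000 nM
Compound 2 `CN(C)CCCNc1c(C(=O)NCc2ccc(F)cc2)nc(Br)c2cccnc12`: 8000 nM

In this assay, going by the values given here, compound 2 stands level with compound 1, and no measured step yet shows what a single change does. Compound 3 `N[C@H]1CC[C@H](Nc2c(C(=O)NCc3ccc(F)cc3)nc(Br)c3cccnc23)CC1` departs from compound 2 by one substitution on a nitrogen on an aromatic ring: 4-aminocyclohexyl in place of 3-(dimethylamino)propyl on a nitrogen on an aromatic ring. With only these two matching values as a guide, the expected change is small, and a 1.3-fold lower number from compound 2 to compound 3 (0.12 log units; within the scatter) is estimated to stay within the scatter, in the direction of a slightly stronger inhibitor if anything. For compound 3 the estimated value is 6000 nM, with an expected range of 2000 nM to 20000 nM.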

Compound 3, half-maximal inhibitory concentration: 5000 nM
The estimate for compound 3 lay 1.2-fold (0.08 log units) above the measured number; the measured number falls inside the stated range.
By their numbers in this assay, from the lowest: compounds 3, 1 and 2 (each within the scatter of the next).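

In this assay, putting 4-aminocyclohexyl in place of 3-(dimethylamino)propyl on a nitrogen on an aromatic ring gives a 1.6-fold lower number from compound 2 to compound 3 (0.20 log units; within the scatter), so a carbon ring serves here as well as the open chain. With 4-aminocyclohexyl kept, one bromine atom in place of the group of 8 heavy atoms on an aromatic carbon gives a 1.6-fold lower number from compound 1 to compound 3 (0.20 log units; within the scatter), so neither change moves the number beyond the scatter. No measurement at hand offers a reason for these readings. From the compounds shown here alone, whether a longer chain ending in a carboxylic acid on that nitrogen would shift the number remains open. So does the effect of a chlorine atom or a morpholine on the aromatic carbon.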